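The source may hold more compounds than are shown below. What is called first, only, known or untested is meant among the compounds shown, and "the series" means these compounds.

Measured so far:
- compound 1, `c1cc(-c2cn[nH]c2)c2c(c1)C(c1ncc[nH]1)CC2`: 14 nM
- compound 2, `CCS(=O)(=O)Nc1cccc2c1CCC2c1ncc[nH]1`: 32 nM
- compound 3, `CNC(=O)c1cccc2c1CCC2c1ncc[nH]1`: 2200 nM

All three share one core and differ only in the group on one aromatic carbon. In a functional assay on CHO cells for agonist activity at Alpha-1A adrenergic receptor (Homo sapiens), read by FLIPR and calcium flux (a lower number here means that less compound is needed, a higher number that more compound is needed for the effect), compound 1 gives the lowest number, compound 3 the highest. The step from compound 1 to compound 3 is a 160-fold higher number from compound 1 to compound 3 (2.20 log units; beyond the scatter), and the step from compound 2 to compound 3 is a 69-fold higher number from compound 2 to compound 3 (1.84 log units; beyond the scatter), so compound 3 stands well apart from the other two.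

Compound 4, `Cn1ccc(-c2cccc3c2CCC3c2ncc[nH]2)n1`, has not yet been measured. Its change from compound 3 is 1-methyl-1H-pyrazol-3-yl in place of methylcarbamoyl on an aromatic carbon. Within the data shown here, two measured steps bear on this. Compound 1 carries a 1H-pyrazol-4-yl group and its step to compound 3 was large, a 160-fold higher number from compound 1 to compound 3 (2.20 log units; beyond the scatter). Compound 2 carries an (ethylsulfonyl)amino group and its step to compound 3 was also large, a 69-fold higher number from compound 2 to compound 3 (1.84 log units; beyond the scatter). A 1-methyl-1H-pyrazol-3-yl group is again a five-membered aromatic ring with two nitrogens, resembling compound 1 more than compound 3. Compound 4 is therefore expected to show a large step towards a lower number, a 44-fold lower number from compound 3 to compound 4 (1.64 log units; beyond the scatter), though the changed methyl and attachment point leave room for a smaller gain than compound 1 shows. The estimate for compound 4 in this assay is 50 nM, with a likely range from 10 nM to 300 nM.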

Compound 4, half-maximal effective concentration: > 1300 nM
Compound 4: only a limit was reported; the forecaster's own chance of this, stated with the estimate: 3%; at least 26-fold (1.41 log units) between middle value and limit.
By their numbers in this assay, from the lowest: compound 1; then compound 2; then compound 3.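

In this assay compound 4 gives only a limit, > 1300 nM. The 1-methyl-1H-pyrazol-3-yl and 1H-pyrazol-4-yl groups are both five-membered aromatic rings with two nitrogens, yet exchanging one for the other on this aromatic carbon gives an at least 92-fold higher number from compound 1 to compound 4 (1.96 log units; beyond the scatter), while replacing (ethylsulfonyl)amino with the methylated ring gives an at least 40-fold higher number from compound 2 to compound 4 (1.60 log units; beyond the scatter). Having such a ring at this place is therefore not enough for a low number, although the step from compound 3 to compound 4 cannot be read, so the order of those two remains unknown.

Compound 1 and compound 4 differ in both the methyl and the ring's attachment point, so the shown data cannot say which matters. A 1-methyl-1H-pyrazol-4-yl group on this carbon would separate the two.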